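A few compounds are considered here, and "the series" means these few. Any claim that something is new, unique, unknown or untested is made for them only; others in the source may bear on it.

Measured so far in a functional assay on A549 cells (Homo sapiens) for cytotoxicity, read by MTT assay, with a stated time of 72 h; a lower number here means that less compound is needed, a higher number that more compound is needed for the effect:
- compound 1 `CCc1cccc2c(O)c(-c3occ(C)c3C(=O)O)ccc12` gives 10.6 ug/mL
- compound 2 `CCc1cccc2c(OC)c(-c3occ(C)c3C(=O)OC)ccc12` gives 1.5 ug/mL
- compound 3 `CCOC(=O)c1c(C)coc1-c1ccc2c(CC)cccc2c1OC` gives 3.8 ug/mL

Compound 3 stands in the middle of these three numbers. Its 3.8 ug/mL lies above the number of compound 2 and below the number of compound 1.

The next compound, compound 4 `CCCOC(=O)c1c(C)coc1-c1ccc2c(CC)cccc2c1OC`, differs from compound 3 in one place: ethoxy to propoxy. The computed difference is methyl in place of hydrogen on a saturated chain carbon, two bonds along the chain from an oxygen next to a carbonyl group as the change. It is methyl in place of hydrogen on a saturated chain carbon, two bonds along the chain from an oxygen next to a carbonyl group.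

Among the compounds with values here, only one measured step bears on this: a 2.5-fold higher number from compound 2 to compound 3 (0.40 log units; beyond the scatter) for methyl in place of hydrogen on a saturated chain carbon bound to an oxygen next to a carbonyl group. That step was modest and went towards a higher number. Within the data shown here, it sits at a different place on the chain, so it offers only loose guidance, and the data hold no measured step at the new place. A smaller step in the same direction in this assay is therefore expected, possibly no more than scatter.

The expected step is a 1.4-fold higher number from compound 3 to compound 4 (0.16 log units; within the scatter) in this estimate. Compound 4 is estimated at 5.5 ug/mL with an expected range of 2.5 ug/mL to 12 ug/mL for the measurement.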

Compound 4, concentration for half-maximal effect: > 10 ug/mL
Compound 4: no number, only a limit; the forecaster's own chance of this, stated with the estimate: 3%; middle value at least 1.8-fold (0.25 log units) away from the limit.
By their numbers in this assay, from the lowest: compound 2; then compound 3; then compound 1.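

Ethoxy to propoxy gives the first reading at a saturated chain carbon, two bonds along the chain from an oxygen next to a carbonyl group, and in this assay this change gives an at least 2.6-fold higher number from compound 3 to compound 4 (0.42 log units; beyond the scatter) and so carries the rise in the number beyond the scatter at this further place too. Among the three esters the trend now runs in one direction, with a 2.5-fold higher number from compound 2 to compound 3 (0.40 log units; beyond the scatter) for the first extension and an at least 6.6-fold higher number from compound 2 to compound 4 (0.82 log units; beyond the scatter) over the whole change from the methyl ester to the propyl ester, and none of these three compounds goes against it. Compound 4 has no number in this assay, only a limit: the limit of > 10 ug/mL in this assay, at which 1 of the 4 values shown sits.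

That limit leaves the full size of both new steps open, so the data cannot say how much of the response is lost from the ethyl ester to the propyl ester. Also open is how the number would respond to a butoxy chain, a branched isopropoxy group or an amide in place of the ester, since the compounds shown cover only straight chains up to propoxy.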